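A few compounds are considered here, and "the series" means these few. Any claim that something is new, unique, unknown or untested is made for them only; others in the source may bear on it.

Series notes. For the measured compounds named here, in a functional assay on MDA-MB-231 cells (Homo sapiens) for inhibition, read by sulforhodamine B assay, tested at 10 uM (a higher number here means more inhibition at the concentration tested (going by the name of the read-out), a lower number less inhibition), compound 1 `CC(=O)N1N=C(c2ccc(N3CCN(C)CC3)cc2)CC1c1ccc(N(C)C)cc1` gives -1% and compound 2 `CN1CCN(c2ccc(C3=NN(S(=O)(=O)C4CC4)C(c4ccc(N(C)C)cc4)C3)cc2)CC1` gives 3.7%; the only measured step so far is a number 4.7 percentage points higher from compound 1 to compound 2 (within the scatter). Compound 3 `CN(C)c1ccc(C2CC(c3ccc(-n4cncn4)cc3)=NN2C(=O)c2cc(Cl)cc(Cl)c2)cc1` gives 9.4% in this assay, the highest of the three numbers, with its gap to compound 2 within the scatter and its gap to compound 1 beyond it. Compound 4 `CN(C)c1ccc(C2CC(c3ccc(-n4cncn4)cc3)=NN2S(=O)(=O)c2ccc(Br)cc2)cc1` differs from compound 3 by (4-bromophenyl)sulfonyl in place of (3,5-dichlorophenyl)carbonyl on an amine nitrogen in a ring. The step that bears on this exchange is a number 4.7 percentage points higher from compound 1 to compound 2 (within the scatter), likewise a sulfonyl put in place of an acyl group on an amine nitrogen in a ring, and it stayed within the scatter; so for compound 4 in this assay no step beyond the scatter is expected in either direction, an estimated a number 0.6 percentage points higher from compound 3 to compound 4 (within the scatter). Compound 4 is therefore expected to give about 10%, in the range -5% to 25%.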

Compound 4, a percentage reported as inhibition, at one concentration (the size of the read-out at that concentration, not a potency): 10.4%
Beside the measured number, compound 4's estimate is 0.4 percentage points below it; the measured number falls inside the stated range.
By their numbers in this assay, from the lowest: compounds 1, 2, 3 and 4 (each within the scatter of the next, the first and the last beyond it).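

On the amine nitrogen in the ring, with the 4-(1H-1,2,4-triazol-1-yl)phenyl group held constant, a full aryl exchange also leaves this assay essentially unmoved: (4-bromophenyl)sulfonyl in place of (3,5-dichlorophenyl)carbonyl gives (a number 1 percentage points higher from compound 3 to compound 4 (within the scatter)). A sulfonyl for an acyl group thus stays within the scatter here with an aromatic ring on the linker, not only with the small groups of the earlier step. Nothing available explains this. Open, as far as these compounds go, is whether an amine or a carboxylic acid on a longer chain at this nitrogen would move the read-out beyond the scatter.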